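The source may hold more compounds than are shown below. What is called first, only, known or untested is meant among the compounds shown, and "the series" means these compounds.

Measured in a functional assay on MCF7 cells (Homo sapiens) for inhibition, read by MTT assay, with a stated time of 48 h; a lower number here means a stronger inhibitor, a higher number a weaker inhibitor:
- Compound 1 `COc1ccc(C(=O)C=CNc2cc(-c3ccccc3)nn2-c2ccccc2)cc1` gives 1290 nM
- Compound 2 `c1ccc(-c2nn(-c3ccccc3)c3nccc(-c4cccs4)c23)cc1` gives 39300 nM
- Compound 3 `N#Cc1c(-c2ccc(Cl)cc2)nc2c(c(-c3ccccc3)nn2-c2ccccc2)c1-c1ccc(N2CCCCC2)cc1` gives 10600 nM

Compound 2, at 39300 nM in this set, has the highest number of the three and is the weakest inhibitor. Compound 4 `COc1ccc(-c2ccnc3c2c(-c2ccccc2)nn3-c2ccccc2)cc1` has 4-methoxyphenyl in place of thiophen-2-yl on an aromatic carbon. For the measured compounds named here, no measured pair differs in only one place, so the data do not directly show what this swap does. In this assay no shift beyond the scatter is expected, only a slight drift toward a lower number. The estimated step (a 1.6-fold lower number from compound 2 to compound 4 (0.20 log units; within the scatter)) is therefore small. The expected value for compound 4 is 25000 nM with an estimated range of 8000 nM to 70000 nM as the likely span.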

Compound 4, half-maximal inhibitory concentration: 28700 nM
The estimate for compound 4 lay 1.1-fold (0.06 log units) below the measured number; the range from low to high includes it.
By their numbers in this assay, from the lowest: compound 1; then compound 3; then compounds 4 and 2 (each within the scatter of the next).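

Placing 4-methoxyphenyl in place of thiophen-2-yl on this aromatic carbon gives the first comparison in which only one place differs, and in this assay it yields a 1.4-fold lower number from compound 2 to compound 4 (0.14 log units; within the scatter). Here, a six-membered aromatic ring of carbon only with a methoxy group and a five-membered aromatic ring with a hetero atom cannot be told apart by this read-out. From the compounds shown here alone, whether an amine or a carboxylic acid on this carbon would shift the number beyond the scatter remains open. No available evidence explains the similarity of these two compounds.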